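The source may report more compounds than this note shows. Statements on the series, on what has been measured and on what is new or still open speak of the compounds shown alone.

Three close relatives share one core and differ only in a single group on an aromatic carbon. In a physicochemical assay for solubility, read by chemiluminescence, measured as kinetic solubility (on this read-out higher numbers stand for higher solubility and lower numbers for lower solubility), compound 1 `CC(=O)NCc1cccc(Cn2nc(NS(=O)(=O)c3ccc(Cl)s3)c3c(F)cccc32)c1` gives >= 139 ug/mL, which is a limit of the assay and not a number. Compound 2 `CC(=O)NCc1cccc(Cn2nc(NS(=O)(=O)c3ccc(Cl)s3)c3c(CO)cccc32)c1` gives >= 113 ug/mL, also a limit. Compound 3 `CC(=O)NCc1cccc(Cn2nc(NS(=O)(=O)c3ccc(Cl)s3)c3c(C(C)(C)O)cccc32)c1` gives >= 159 ug/mL, and this too is only a limit, so compound 3 has no exact place on the scale, and neither do the two other compounds.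

The next compound, compound 4 `CC(=O)NCc1cccc(Cn2nc(NS(=O)(=O)c3ccc(Cl)s3)c3c(C(F)F)cccc32)c1`, carries difluoromethyl in place of 1-hydroxy-1-methylethyl on an aromatic carbon. For the measured compounds named here, three measured steps bear on this change: a step that the two limits leave unreadable from compound 1 to compound 2, a step that the two limits leave unreadable from compound 1 to compound 3 and a step that the two limits leave unreadable from compound 2 to compound 3. None of them has a readable size, so they offer no measured effect to carry over. They do show that all three groups tried at this place left the compounds reporting limits in this assay. The closest guide is compound 1, which carries fluoro there and whose >= 139 ug/mL is again a limit.

The expectation is no step beyond the usual scatter, in either direction, and another limit is the likeliest result. The estimated change is an at least 1.2-fold lower number from compound 3 to compound 4 (0.08 log units; that floor lies within the scatter). For compound 4 the estimated value is 130 ug/mL, with an expected range of 60 ug/mL to 175 ug/mL.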

Compound 4, solubility: >= 188 ug/mL
Compound 4: no number, only a limit (the forecaster's own chance of this, stated with the estimate: 65%); middle value at least 1.4-fold (0.16 log units) away from the limit.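

Compound 4 reports only a limit in this assay, and compound 1, compound 2 and compound 3 do too, so the steps from these three to compound 4 cannot be read. The compounds shown leave open where any of the four truly sits on the scale, and whether swapping the group on this aromatic carbon shifts the read-out at all.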